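The source may hold more compounds than are shown below. What is called first, only, known or untested is meant among the compounds shown, and "the series" means these compounds.

For the measured compounds named here, compound 3 `COc1cccc(-c2cc(-c3cc(C(C)C)c(O)cc3C)[nH]c(=O)c2C#N)c1` gives 49% in a functional assay for inhibition, tested at 100 ug/mL (on this read-out lower numbers stand for a weaker effect and higher numbers for a stronger effect at the one concentration tested), the second highest of the three numbers measured so far. Compound 1 `Cc1cc(O)c(C(C)C)cc1-c1cc(-c2ccccc2)c(C#N)c(=O)[nH]1` gives 41% in this assay, and compound 2 `COc1cc(-c2cc(-c3cc(C(C)C)c(O)cc3C)[nH]c(=O)c2C#N)cc(OC)c1OC` gives 84.5%, well above the other two. Going by the values given here, the one single-point step known so far, methoxy in place of hydrogen on an aromatic carbon, moved this assay a number 8 percentage points higher from compound 1 to compound 3 (within the scatter). Compound 4 `Cc1cc(O)c(C(C)C)cc1-c1cc(-c2cccs2)c(C#N)c(=O)[nH]1` differs from compound 3 by thiophen-2-yl in place of 3-methoxyphenyl on an aromatic carbon. Among the compounds with values here, no measured step exchanges one aromatic ring for another, so the step from compound 1 to compound 3, which stayed within the scatter, is the only guide, and compound 1 without the methoxy is the closer reference. The step of a number 5 percentage points lower from compound 3 to compound 4 (within the scatter) is therefore expected to stay within the scatter. Compound 4 is estimated at 44%, between 22% and 68%.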

Compound 4, a percentage reported as inhibition, at one concentration (the size of the read-out at that concentration, not a potency): 68%
Compound 4: the middle estimate sits 24 percentage points below what was measured; the range from low to high includes it.
By their numbers in this assay, from the lowest: compounds 1 and 3 (each within the scatter of the next); then compound 4; then compound 2.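

In this assay, exchanging the ring itself at this position, opposite the ring nitrogen, moves the read-out further than the added methoxy did: thiophen-2-yl gives a number 19 percentage points higher from compound 3 to compound 4 (beyond the scatter) and, in place of phenyl, a number 27 percentage points higher from compound 1 to compound 4 (beyond the scatter). So a five-membered aromatic ring with one sulfur atom outperforms both six-membered carbon rings here. Nothing measured here explains this difference. Furan-2-yl would help show whether the sulfur or the ring size matters. On these data alone, how a non-aromatic group, such as cyclohexyl or an amine, behaves here remains open.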